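Methylating the Amide Nitrogen of a Benzimidazole Amide

This account rests on a few compounds, and the source may have more. Where it says the series, first, only, none or still open, it means among the compounds named here.

Compound 2 `O=C(Nc1nc2ccccc2[nH]1)c1cccc(Cl)c1` holds the lower of the two numbers measured in an assay on BV-2 cells for positive allosteric modulation of metabotropic glutamate receptor 5 (Mus musculus), read by Griess assay, with stated times of 1 h and 24 h (a lower number here means a stronger inhibitor, a higher number a weaker inhibitor), where compound 2 gives 29000 nM. Compound 1 `O=C(Nc1nc2ccccc2[nH]1)c1ccccc1C(F)(F)F` gives 88000 nM in this assay; the two values differ beyond the usual scatter. Compound 3 `CN(C(=O)c1cccc(Cl)c1)c1nc2ccccc2[nH]1` has not yet been measured in this assay. It differs from compound 2 by methyl in place of hydrogen on an amide-type nitrogen. Among the compounds with values here, no measured pair shows such a change, so the expectation rests on compound 2 alone and on 29000 nM. A modest weakening step a 2.1-fold higher number from compound 2 to compound 3 (0.32 log units; beyond the scatter) is expected, and compound 3 is estimated at 60000 nM, within a range from 15000 nM to 250000 nM.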

Compound 3, half-maximal inhibitory concentration: 210000 nM
Beside the measured number, compound 3's estimate is 3.5-fold (0.54 log units) below it; the measured number falls inside the stated range.
By their numbers in this assay, from the lowest: compound 2; then compound 1; then compound 3.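

Methyl in place of hydrogen on the amide-type nitrogen brings a 7.2-fold higher number from compound 2 to compound 3 (0.86 log units; beyond the scatter) in this assay, the first step read at this position. In this one pair, the amide hydrogen cannot give way to methyl without a loss beyond the scatter. No evidence on hand bears on this result.

Going by these compounds, whether an ethyl group or a longer chain on this nitrogen would move the number further stays open. So does whether the same methyl change would have a similar effect when made on compound 1, which carries trifluoromethyl.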